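This account rests on a few compounds, and the source may have more. Where it says the series, first, only, none or still open, it means among the compounds named here.

Measured so far in a functional assay on K562 cells (Homo sapiens) for antiproliferative activity, read by MTT assay, with a stated time of 72 h; on this read-out lower numbers stand for stronger inhibition and higher numbers for weaker inhibition:

Compound 1 `COc1cc(-n2ncnc2-c2ccc(C)cc2)cc(OC)c1OC`: > 10000 nM
Compound 2 `COc1cc(-c2ncnn2-c2ccc(Cl)cc2Cl)cc(OC)c1OC`: > 10000 nM
Compound 3 `COc1cc(-c2ncnn2-c2ccc([N+](=O)[O-])cc2)cc(OC)c1OC`: > 10000 nM

Compound 1 gives > 10000 nM, and this is a limit, not a number. Compounds 2 and 3 are also limits, so the whole set reads (the limit of > 10000 nM in this assay, at which 3 of the 3 values shown sit). For the measured compounds named here, none of the three can therefore be ranked against another, and no measured pair differs in just one place, so no step size is known from the data.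

Compound 4 `COc1cc(-n2ncnc2-c2ccc(Cl)c(Cl)c2)cc(OC)c1OC` keeps the core of compound 1 and changes one group, with 3,4-dichlorophenyl in place of 4-methylphenyl on an aromatic carbon.

Compound 1 offers only its limit of > 10000 nM as a starting point, and both other measured compounds share that limit. On that basis, the expected step that the limit leaves unreadable from compound 1 to compound 4 in this assay is none beyond the scatter, in either direction. For compound 4 the estimate is 12000 nM, within an expected range of 5000 nM to 30000 nM.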

Compound 4, half-maximal inhibitory concentration: > 10000 nM
Compound 4 was reported as a limit; the forecaster's own chance of this, stated with the estimate: 85%; the middle value lies beyond the limit too.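

In this assay, for the compounds shown here, compound 1 and compound 4 are both reported only as limits, so no step between them can be read, and the whole set looks the same: the limit of > 10000 nM in this assay, at which 4 of the 4 values shown sit.

The compounds shown leave open whether swapping 4-methylphenyl for 3,4-dichlorophenyl changes activity at all.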